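The source may report more compounds than this note shows. Statements on the series, on what has been measured and on what is new or still open speak of the compounds shown alone.

In a physicochemical assay for lipophilicity, using the shake flask method, measured as octanol-water partition, at pH 7.4 (on this read-out higher numbers stand for higher lipophilicity and lower numbers for lower lipophilicity), compound 1 (`COc1ccc(C2CC(=O)NCCS2)cc1`) reads 1.6 and compound 2 (`O=c1[nH]ccc2nc(-c3ccccc3)cn12`) reads 2 on this scale. Compound 3 (`O=C(CC1SCCNC1=O)Nc1ccccc1`) stands lowest of the three at 0.8 on the same scale, beyond the scatter from both compound 1 and compound 2, and furthest from compound 2.

Compound 4 (`O=C(CC1SCCNC1=O)Nc1ccc(F)cc1`) is still unmeasured and differs from compound 3 in one place (fluoro in place of hydrogen on an aromatic carbon), with fluoro in place of hydrogen on an aromatic carbon. Among the measured compounds shown here, no measured pair in this set differs in one place, and the data offer no calibration for this change. Only a small upward step is expected in this assay, one that stays within the scatter of repeat measurements. The expected step is a number 0.20 log units higher from compound 3 to compound 4 (within the scatter) on this read-out. For compound 4 the estimated value is 1 with an expected range of 0.7 to 1.3 pending measurement.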

Compound 4, distribution coefficient: 1.2
For compound 4 the middle estimate is 0.20 log units below the measured one; the range from low to high includes it.
By their numbers in this assay, from the lowest: compound 3; then compound 4; then compound 1; then compound 2.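

In this assay, among the compounds shown here, fluoro in place of hydrogen on an aromatic carbon, para to a large group, gives a number 0.40 log units higher from compound 3 to compound 4 (beyond the scatter) and so provides the first step that can be read at a single place. The earlier compounds shown here, which differ from each other in more than one place, could not show that this aromatic carbon responds to this change at all. The reading rests on one pair, so it holds for this position on this core and sets no trend, and no measurement at hand accounts for the size of the step.

As far as these compounds go, whether a chloro group, an amine or a carboxylic acid on the same aromatic carbon would move the number in the same direction stays open. Also open, from the compounds shown here alone, is whether fluoro gives a similar step on the aromatic ring of a different core.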